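Trihalophenyl sulfonamides: halogen swap from compound 3 to compound 4

The compounds below may be only part of what the source reports. "The series", "measured", "known", "first", "only" and "open" are said of these compounds alone.

Three members of the series have been measured in an assay on isolated protein for binding affinity to 5-hydroxytryptamine receptor 6 (Homo sapiens); a higher number here means a weaker inhibitor, a lower number a stronger inhibitor. Compound 1 `COc1ccc(S(=O)(=O)Nc2c(F)cc(Br)cc2F)cc1N1CCNCC1`, carrying a 4-bromo-2,6-difluorophenyl on the sulfonamide nitrogen, gives 158 nM. Compound 2 `COc1ccc(S(=O)(=O)Nc2cc(Cl)c(Cl)cc2Cl)cc1N1CCNCC1`, with a 2,4,5-trichlorophenyl in that place, gives 5.01 nM; the step of a 32-fold lower number from compound 1 to compound 2 (1.50 log units; beyond the scatter) is large. Compound 3 `COc1ccc(S(=O)(=O)Nc2cc(Br)cc(Br)c2Br)cc1N1CCNCC1`, with a 2,3,5-tribromophenyl, gives 2.51 nM. Compound 3 thus stands at the low end of the three numbers: the step of a 2.0-fold lower number from compound 2 to compound 3 (0.30 log units; within the scatter) is within the scatter, so compound 2 and compound 3 cannot be told apart here, whereas the step of a 63-fold lower number from compound 1 to compound 3 (1.80 log units; beyond the scatter) is large and beyond the scatter.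

The next step leads to compound 4 `COc1ccc(S(=O)(=O)Nc2cc(Cl)cc(Br)c2Cl)cc1N1CCNCC1`. The change is 3-bromo-2,5-dichlorophenyl in place of 2,3,5-tribromophenyl on a sulfonamide nitrogen. The arrangement of three halogens on the ring is kept; two bromines become chlorines. The step that bears most directly on this is the change from compound 2 to compound 3, which exchanged chlorines for bromines and a different arrangement and stayed within the scatter; the large steps from compound 1 involved a different halogen pattern entirely and are not the closest guide. A step within the scatter is therefore expected for compound 4, in either direction, giving an estimated 1.4-fold higher number from compound 3 to compound 4 (0.14 log units; within the scatter). The expected value for compound 4 in this assay is 3.5 nM, with a range from 1.5 nM to 10 nM.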

Compound 4, inhibition constant: 2 nM
Estimate against measurement, compound 4: 1.8-fold (0.24 log units) above, and the stated range covers the measured number.
By their numbers in this assay, from the lowest: compounds 4, 3 and 2 (each within the scatter of the next, the first and the last beyond it); then compound 1.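

Working notes: in this assay, the pair of compound 3 and compound 4 is the first to keep the arrangement of the three halogens and change only their identity, with two bromines becoming chlorines, and a 1.3-fold lower number from compound 3 to compound 4 (0.10 log units; within the scatter) shows that this exchange cannot be told apart from no change at this position on the sulfonamide nitrogen. The other two steps differ in both halogen identity and arrangement: a 2.5-fold lower number from compound 2 to compound 4 (0.40 log units; beyond the scatter) gives the first separation beyond the scatter among the three heavily halogenated compounds, though it is modest and compound 3 is within the scatter of both compound 2 and compound 4, while a 79-fold lower number from compound 1 to compound 4 (1.90 log units; beyond the scatter) keeps compound 1 well apart from the rest of the series. Nothing measured here accounts for any of these steps.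

The series holds too few pairs to separate halogen identity from arrangement in general, as only compound 3 and compound 4 share one arrangement. Going by these compounds, it also remains open whether a nitrile, a trifluoromethyl or an amine could stand in place of the bromine in the 3-bromo-2,5-dichlorophenyl and keep the number in this range.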